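Benzothiazole in place of benzimidazole on the shared core

The source may report more compounds than this note shows. Statements on the series, on what has been measured and on what is new or still open speak of the compounds shown alone.

Compound 1 `O=P(O)(O)OP(=O)(O)OP(=O)(O)OC[C@H]1O[C@@H](c2nc3ccc(Cl)cc3s2)[C@H](O)[C@@H]1O` gives 8 nM in a functional assay for agonist activity at P2Y purinoceptor 2 (Homo sapiens), read by FLIPR; a higher number here means that more compound is needed for the effect, a lower number that less compound is needed.
Compound 2 `Cn1c([C@@H]2O[C@H](COP(=O)(O)OP(=O)(O)OP(=O)(O)O)[C@@H](O)[C@H]2O)nc2ccccc21` gives 200 nM in this assay.
Compound 3 `O=P(O)(O)OP(=O)(O)OP(=O)(O)OC[C@H]1O[C@@H](c2nc3c(F)cc(Cl)cc3s2)[C@H](O)[C@@H]1O` gives 7 nM in this assay.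

Compound 2 stands highest of the three numbers in this assay; the nearest is compound 1, with a 25-fold higher number from compound 1 to compound 2 (1.40 log units; beyond the scatter), and compound 3 lies further still. Compound 4 `O=P(O)(O)OP(=O)(O)OP(=O)(O)OC[C@H]1O[C@@H](c2nc3ccccc3s2)[C@H](O)[C@@H]1O` carries 1,3-benzothiazol-2-yl in place of 1-methyl-1H-benzimidazol-2-yl on a saturated ring carbon. The step of a 25-fold higher number from compound 1 to compound 2 (1.40 log units; beyond the scatter) bears most directly on this change, which reverses it apart from the chloro group that compound 4 does not carry; the step of a 1.1-fold lower number from compound 1 to compound 3 (0.06 log units; within the scatter) shows a change on the aromatic ring of compound 1 staying within the scatter. A large fall in this assay is therefore expected, its full extent uncertain. Compound 4 is expected at 20 nM (range 6 nM to 70 nM), an estimated 10-fold lower number from compound 2 to compound 4 (1.00 log units; beyond the scatter).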

Compound 4, half-maximal effective concentration: 22 nM
For compound 4 the middle estimate is 1.1-fold (0.04 log units) below the measured one; measured number inside the range.
By their numbers in this assay, from the lowest: compounds 3 and 1 (each within the scatter of the next); then compound 4; then compound 2.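

The change from 1-methyl-1H-benzimidazol-2-yl to 1,3-benzothiazol-2-yl on the saturated ring carbon, read now without the chloro group, gives most of the gap in this assay (a 9.1-fold lower number from compound 2 to compound 4 (0.96 log units; beyond the scatter)). The chloro group makes a smaller but separate contribution (a 2.8-fold higher number from compound 1 to compound 4 (0.44 log units; beyond the scatter)), so both the group on this carbon and the chloro group count. No data on hand explain either step.

Still open, going by these compounds, is how an amine or a methoxy group would compare with chloro on that aromatic carbon. Also open, on these data alone, is how an unmethylated 1H-benzimidazol-2-yl group would read on the saturated ring carbon.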